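Trading the Acetyl Butyl Amide for a Carbamate

The source may report more compounds than this note shows. Statements on the series, on what has been measured and on what is new or still open speak of the compounds shown alone.

In a functional assay for agonist activity at follicle-stimulating hormone receptor (Homo sapiens), read by a luciferase reporter (on this read-out higher numbers stand for an effect only at larger amounts of compound and lower numbers for an effect already at smaller amounts), compound 3 `CCCCCCCCN1C(=O)[C@H](Cc2ccc(-c3cccc(CN(CCCC)C(C)=O)c3)cc2)N(C)C(=O)[C@@H]1C` gives 14 nM, the lowest number among the three compounds measured. Compound 2 `CCCCCCN1C(=O)[C@H](Cc2ccc(-c3cccc(CN(CCCC)C(C)=O)c3)cc2)N(C)C(=O)[C@@H]1C` gives 150 nM, and compound 1 `CCCCCCCN1CC(=O)N(C)[C@@H](Cc2ccc(-c3cc(OC)c(OC)c(OC)c3)cc2)C1=O` gives 2300 nM. Among the compounds with values here, the only single-point step recorded is an 11-fold lower number from compound 2 to compound 3 (1.03 log units; beyond the scatter), showing that a longer chain on the ring nitrogen moves the number by a large margin. Compound 1 differs from the other two in several places at once, so its value serves only as a distant reference.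

Compound 4 `CCCCCCCCN1C(=O)[C@H](Cc2ccc(-c3cccc(CN(COC)C(=O)OC)c3)cc2)N(C)C(=O)[C@@H]1C` differs from compound 3 in a single place: (methoxycarbonyl)(methoxymethyl)amino in place of acetyl(butyl)amino on a saturated chain carbon bound to an aromatic carbon. Within the data shown here, no measured step bears on this site. Among the measured compounds shown here, the one step available, from compound 2 to compound 3, concerns the chain on the ring nitrogen and says nothing about the substituents on the benzylic amide nitrogen. Without precedent, the direction of the change is open, and a moderate shift in either direction would not be surprising, with a loss somewhat more likely than a gain given that compound 3 already holds the best number shown.

Compound 4 is therefore expected to give about 40 nM, with a plausible range from 8 nM to 200 nM. The estimated step of a 2.9-fold higher number from compound 3 to compound 4 (0.46 log units; beyond the scatter) expresses this modest expected loss.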

Compound 4, half-maximal effective concentration: 1.8 nM
For compound 4 the middle estimate is 22-fold (1.35 log units) above the measured one; the measured number lies below the stated range.
By their numbers in this assay, from the lowest: compound 4; then compound 3; then compound 2; then compound 1.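

In this assay, the step to the carbamate gives a 7.8-fold lower number from compound 3 to compound 4 (0.89 log units; beyond the scatter), the first sign in this series that the group on the saturated chain carbon bound to an aromatic carbon can move the number as well as the chain on the ring nitrogen can. Within the data shown here, compound 2 and compound 3 carry the same acetyl(butyl)amino group, so only this step reaches the site, and it shows that the butyl and acetyl parts are not required for a low number here: (methoxycarbonyl)(methoxymethyl)amino does better while matching the heavy-atom count of the group it replaces, with more oxygen and more hydrogen-bond acceptors. Nothing available explains why the number falls with this change.

The change alters both arms of the nitrogen at once, so the compounds shown cannot say whether the methoxycarbonyl or the methoxymethyl part carries the gain; the mixed pairs, methoxycarbonyl with butyl and acetyl with methoxymethyl, would separate the two. Going by these compounds, it also remains open how a free amine or a carboxylic acid at this site would read, and whether a shorter chain on the ring nitrogen costs as much alongside the carbamate as it does alongside the acetyl butyl amide.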